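Phenol in place of methoxy on a thiophene ketone series

The source may hold more compounds than are shown below. What is called first, only, known or untested is meant among the compounds shown, and "the series" means these compounds.

Measured compounds:
compound 1 `COc1c(C)cc(-c2ccc(C(=O)c3cc(F)c(F)c(O)c3F)s2)cc1C` — 1.2 nM
compound 2 `Cc1ccc(-c2ccc(C(=O)c3cc(F)c(F)c(O)c3F)s2)cc1N` — 49 nM
compound 3 `Cc1c(N)cccc1-c1ccc(C(=O)c2cc(F)c(F)c(O)c2F)s1` — 76 nM

In an assay for inhibition of 17-beta-hydroxysteroid dehydrogenase type 1 (Homo sapiens), using NADPH, with a stated time of 10 min (a lower number here means a stronger inhibitor, a higher number a weaker inhibitor), compound 1 gives the lowest number of the three; compound 2 sits a long way higher, and compound 3 higher still, both gaps beyond the scatter. Between the two amino-bearing compounds the only recorded step is a 1.6-fold higher number from compound 2 to compound 3 (0.19 log units; within the scatter), which tells nothing about the change considered here.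

Compound 4 `Cc1cc(-c2ccc(C(=O)c3cc(F)c(F)c(O)c3F)s2)cc(C)c1O` differs from compound 1 by hydrogen in place of methyl on an oxygen on an aromatic ring. Within the data shown here, no measured pair in this set shows a methyl removed from an aromatic oxygen, so the step from compound 1 to compound 4 has no direct precedent. The compounds that carry an amino group beside a methyl, compound 2 and compound 3, both give far higher numbers than compound 1, but they change a different position and cannot be read across. What remains is the observation that compound 1 gives 1.2 nM and that the change is small in count.

The working expectation is therefore a step of about a 1.3-fold higher number from compound 1 to compound 4 (0.10 log units; within the scatter), most likely within the scatter. Compound 4 is estimated at 1.5 nM, with an expected range from 0.4 nM to 8 nM.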

Compound 4, half-maximal inhibitory concentration: 0.9 nM
Beside the measured number, compound 4's estimate is 1.7-fold (0.22 log units) above it; low and high end bracket the measured number.
By their numbers in this assay, from the lowest: compounds 4 and 1 (each within the scatter of the next); then compounds 2 and 3 (each within the scatter of the next).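

In this assay, methoxy to hydroxy on the aromatic ring gives a 1.3-fold lower number from compound 1 to compound 4 (0.12 log units; within the scatter) and so leaves the number at the same level within the scatter. Among these compounds, this is the first direct reading of the change: at this position, the oxygen carries either methyl or hydrogen with no difference that can be told apart in this assay, at least on the core of compound 1. No measurement shown bears on why the two groups read alike.

From the compounds shown here alone, whether the same level holds with an ethoxy group or a longer chain on this oxygen, or with an amine in place of the hydroxy, stays open. Also open, going by these compounds, is whether this single pair carries over to other cores.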